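The source may hold more compounds than are shown below. What is called first, only, known or untested is meant among the compounds shown, and "the series" means these compounds.

Working notes on the series. In an ADME assay on BaF3 cells (Mus musculus) for antiproliferative activity, read by CCK-8 assay, with a stated time of 72 h (on this read-out lower numbers stand for stronger inhibition of growth and higher numbers for weaker inhibition of growth), compound 1 `CN1CCN(c2cccc(NC(=O)CCSc3ccc4c(/C=C/c5ccccn5)n[nH]c4c3)c2)CC1` gives > 10000 nM as a limit of the assay and not a number. Compound 2 `COc1ccc(NC(=O)CCSc2ccc3c(/C=C/c4ccccn4)n[nH]c3c2)cc1C(F)(F)F` gives > 10000 nM as a limit too. For the measured compounds named here, compound 3 `CN1CCN(Cc2ccc(NC(=O)CCSc3ccc4c(/C=C/c5ccccn5)n[nH]c4c3)cc2C(F)(F)F)CC1` gives 2480 nM as the only true number so far, so it stands alone on the scale, with no other number to compare it to.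

Compound 4 `O=C(CCSc1ccc2c(/C=C/c3ccccn3)n[nH]c2c1)Nc1ccc(CN2CCCC2)c(C(F)(F)F)c1` carries pyrrolidin-1-yl in place of 4-methylpiperazin-1-yl on a saturated chain carbon bound to an aromatic carbon is the whole difference.

Going by the values given here, one measured step bears on this, an at least 4.0-fold lower number from compound 2 to compound 3 (0.60 log units; beyond the scatter), which brought in the (4-methylpiperazin-1-yl)methyl group in place of methoxy. Among the compounds with values here, compound 4 keeps the same kind of group, as (pyrrolidin-1-yl)methyl, but no measured step covers the exchange of the ring itself. The expected change is therefore a 1.0-fold higher number from compound 3 to compound 4 (0.00 log units; within the scatter) and no direction is expected beyond the scatter. A return to the limit of > 10000 nM in this assay, at which 2 of the 3 values shown sit, remains possible. For compound 4 the estimated value is 2500 nM with an expected range of 800 nM to 8000 nM in this assay on this evidence.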

Compound 4, concentration for 50% growth inhibition: 4000 nM
Estimate against measurement, compound 4: 1.6-fold (0.20 log units) below; the range from low to high includes it.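

In this assay, pyrrolidin-1-yl in place of 4-methylpiperazin-1-yl on a saturated chain carbon bound to an aromatic carbon gives a 1.6-fold higher number from compound 3 to compound 4 (0.21 log units; within the scatter), so this position tolerates the ring exchange with no change that can be told from the scatter. Replacing methoxy with (pyrrolidin-1-yl)methyl gives an at least 2.5-fold lower number from compound 2 to compound 4 (0.39 log units; beyond the scatter), which shows that the improvement over methoxy is not confined to (4-methylpiperazin-1-yl)methyl. At this place, a ring with 1 hetero atom and a ring with 2 hetero atoms give values within the scatter of each other.

As far as these compounds go, it remains open whether morpholin-4-yl or an open-chain dimethylamino group on the same carbon would keep a measurable value. Also open, from the compounds shown here alone, is how a carboxylic acid in place of the amine would read out.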